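The compounds below may be only part of what the source reports. "The series", "measured", "known", "first", "only" and "open" are said of these compounds alone.

In a functional assay on LNCaP cells (Homo sapiens) for cytotoxicity, read by MTT assay (a higher number here means a weaker inhibitor, a lower number a stronger inhibitor), compound 1 `COc1ccc2cc([C@H](C)c3nnc(SCc4ccc(Cl)cc4)n3-c3ccc(F)cc3)ccc2c1` gives > 400000 nM, which is a limit and not a number. Compound 2 `COc1ccc2cc([C@H](C)c3nnc(SCc4c(C)cc(C)cc4C)n3-c3cccc(Cl)c3)ccc2c1` is also known only as a limit, <= 400000 nM. Compound 3 `COc1ccc2cc([C@H](C)c3nnc(SCc4ccc(Cl)cc4)n3-c3ccc(Cl)cc3)ccc2c1` gives an actual number, 110000 nM.

Compound 4 `COc1ccc2cc([C@H](C)c3nnc(SCc4c(Cl)cccc4Cl)n3-c3ccc(F)cc3)ccc2c1` keeps the core of compound 1 and changes one group: 2,6-dichlorophenyl in place of 4-chlorophenyl on a saturated chain carbon bound to a sulfur. In words, 2,6-dichlorophenyl stands in place of 4-chlorophenyl on a saturated chain carbon bound to a sulfur. Within the data shown here, no measured pair makes this same change, so the evidence is indirect. The nearest guide is a different change, chloro in place of fluoro on an aromatic carbon, which gave an at least 3.6-fold lower number from compound 1 to compound 3 (0.56 log units; beyond the scatter). On that weak support, a modest move toward a lower number is expected in this assay, and the result may again be only a limit. The expected step is an at least 1.3-fold lower number from compound 1 to compound 4 (0.12 log units; that floor lies within the scatter). The estimate for compound 4 is 300000 nM, with an expected range from 120000 nM to 600000 nM.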

Compound 4, half-maximal inhibitory concentration: 12300 nM
Beside the measured number, compound 4's estimate is 24-fold (1.39 log units) above it; the whole stated range lies above it.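

In this assay, the group on a saturated chain carbon bound to a sulfur turns out to matter a great deal: with nothing else in the structure changed, 2,6-dichlorophenyl in place of 4-chlorophenyl gives an at least 32-fold lower number from compound 1 to compound 4 (1.51 log units; beyond the scatter) in this one swap. Among these compounds, the only earlier step was an at least 3.6-fold lower number from compound 1 to compound 3 (0.56 log units; beyond the scatter) for chloro in place of fluoro on an aromatic carbon, so the number is now seen to move at a second place in the structure as well. As far as these compounds go, the true size of the new step stays unknown, as compound 1 is known only as a limit: the limit of > 400000 nM in this assay, at which 1 of the 4 values shown sits.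

This single swap changes both the number of chlorines and where they sit on the ring, so the two effects cannot be told apart. From the compounds shown here alone, how an amine or a carboxylic acid on this ring, or a longer chain at this place, would behave also remains open.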